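This account rests on a few compounds, and the source may have more. Where it says the series, first, only, none or still open, it means among the compounds named here.

In an ADME assay on microsomes from liver (Homo sapiens) for metabolic stability, read by LC-MS, using NADPH, with a stated time of 60 min, tested at 1 uM (a higher number here means faster removal of the compound, a lower number slower removal), compound 1 (`CNC(=O)c1cc(S(=O)(=O)N2CCS[C@H]2C(=O)O[C@@H](Cc2c(Cl)c[n+]([O-])cc2Cl)c2ccc(OC(F)F)c(OCC3CC3)c2)cn1C`) gives 202 mL.min-1.g-1. Compound 2 (`CN(C)C(=O)c1cccc(S(=O)(=O)N2CSC[C@H]2C(=O)O[C@@H](Cc2c(Cl)c[n+]([O-])cc2Cl)c2ccc(OC(F)F)c(OCC3CC3)c2)c1`) gives 268 mL.min-1.g-1, and compound 3 (`COc1ccc(S(=O)(=O)N2CCC[C@H]2C(=O)O[C@@H](Cc2c(Cl)c[n+]([O-])cc2Cl)c2ccc(OC(F)F)c(OCC3CC3)c2)cc1C(=O)N(C)C`) gives 365 mL.min-1.g-1. These three numbers all lie within the usual scatter of one another, so compound 1 cannot be told apart from either neighbour. Compound 4 (`Cn1cnc(S(=O)(=O)N2CCS[C@H]2C(=O)O[C@@H](Cc2c(Cl)c[n+]([O-])cc2Cl)c2ccc(OC(F)F)c(OCC3CC3)c2)c1`) keeps the core of compound 1 and swaps one group on the sulfonyl sulfur: a group of 6 heavy atoms (4 carbon, 2 nitrogen; one five-membered aromatic ring with 2 hetero atoms) in place of a group of 10 heavy atoms (7 carbon, 2 nitrogen, 1 oxygen; one five-membered aromatic ring with 1 hetero atom), on a sulfonyl sulfur. Going by the values given here, no measured pair isolates a change like this one. Compound 1 at 202 mL.min-1.g-1 and compound 3 at 365 mL.min-1.g-1 carry different groups there, yet stay within the scatter, so no clear shift in either direction is expected. The estimated step of a 1.0-fold lower number from compound 1 to compound 4 (0.00 log units; within the scatter) therefore lies within the scatter. For compound 4 the estimated value is 200 mL.min-1.g-1, with an expected range from 110 mL.min-1.g-1 to 360 mL.min-1.g-1.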

Compound 4, intrinsic clearance in microsomes: 281 mL.min-1.g-1
The estimate for compound 4 lay 1.4-fold (0.15 log units) below the measured number, and the stated range covers the measured number.
By their numbers in this assay, from the lowest: compounds 1, 2, 4 and 3 (each within the scatter of the next).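

Swapping the larger group on the sulfonyl sulfur for 1-methyl-1H-imidazol-4-yl gives the first direct comparison at this position, and in this assay it brings a 1.4-fold higher number from compound 1 to compound 4 (0.14 log units; within the scatter) with the rest of the molecule unchanged. This position therefore accepts a much smaller group with 0 hydrogen-bond donors, in place of one with 1, without a clear shift in removal. No measurement here explains this result.

Still open, on these data alone, is whether a group such as an amine or a carboxylic acid on the sulfonyl sulfur's substituent would move the number beyond the scatter. The same swap on the other cores also remains untested by any pair shown.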